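The source may report more compounds than this note shows. Statements on the series, on what has been measured and on what is new or still open speak of the compounds shown alone.

Of the compounds shown here, three that share one core have been measured in a functional assay on CWR22R cells (Homo sapiens) for antiproliferative activity, read by propidium iodide staining, with a stated time of 96 h; a higher number here means a weaker inhibitor, a lower number a stronger inhibitor. There, compound 1 (`CC(O)(CSc1cccc(S(F)(F)(F)(F)F)c1)C(=O)Nc1ccc(S(F)(F)(F)(F)F)cc1`) gives 17700 nM, compound 2 (`CC(O)(CSc1cccc(S(F)(F)(F)(F)F)c1)C(=O)Nc1cccc(S(F)(F)(F)(F)F)c1`) gives 17200 nM and compound 3 (`CC(O)(CSc1ccc(C(F)(F)F)cc1)C(=O)Nc1cccc(S(F)(F)(F)(F)F)c1`) gives 26900 nM. Compound 2 therefore stands level with compound 1 and compound 3, as all three values lie within the usual scatter of repeated measurements and cannot be ranked.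

Compound 4 (`CC(O)(CSc1cccc(OC(F)(F)F)c1)C(=O)Nc1cccc(S(F)(F)(F)(F)F)c1`) has not yet been measured. It differs from compound 2 in one place: a group of 5 heavy atoms (1 carbon, 1 oxygen, 3 fluorine; no ring) in place of a group of 6 heavy atoms (5 fluorine, 1 sulfur; no ring), on an aromatic carbon. A trifluoromethoxy group replaces a group of 5 fluorine atoms and 1 sulfur atom on an aromatic carbon. Among the compounds with values here, no measured pair shows this change alone, so its effect cannot be read directly from the data.

The closest guide is the narrow spread of values, with compound 3 at 26900 nM within the scatter of compound 2 at 17200 nM. No step beyond the scatter is expected in this assay, and no direction is favoured. The expected change is a 1.2-fold higher number from compound 2 to compound 4 (0.07 log units; within the scatter). Compound 4 is estimated at 20000 nM, with an expected range of 10000 nM to 40000 nM.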

Compound 4, half-maximal inhibitory concentration: 18700 nM
Compound 4: the middle estimate sits 1.1-fold (0.03 log units) above what was measured, within the range that was stated.
By their numbers in this assay, from the lowest: compounds 2, 1, 4 and 3 (each within the scatter of the next).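

In this assay, replacing the group of 5 fluorine atoms and 1 sulfur atom with trifluoromethoxy on this aromatic carbon, meta to a large group, gives a 1.1-fold higher number from compound 2 to compound 4 (0.04 log units; within the scatter). This is the only comparison among the compounds shown that isolates a single change, and it shows that this position accepts the swap without a step beyond the scatter, even though the entering group carries a hydrogen-bond acceptor and the leaving group carries none. Nothing measured here explains why the two groups read alike.

On these data alone, both groups carry fluorine, so it remains open whether a group without fluorine, such as an amine or a carboxylic acid, would also read alike at this position. As far as these compounds go, it also remains open whether the same swap on the amide side of the molecule would give a similar result.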